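A few compounds are considered here, and "the series" means these few. Any claim that something is new, unique, unknown or untested is made for them only; others in the source may bear on it.

Of the compounds shown here, two that share one core have been tested in an ADME assay on L1210/0 cells (Mus musculus) for cytotoxicity, with a stated time of 48 h; a higher number here means a weaker inhibitor, a lower number a stronger inhibitor. Compound 1, `CS(=O)(=O)Cc1cn([C@H]2C[C@H](O)[C@@H](CO)O2)c(=O)[nH]c1=O`, carries a (methylsulfonyl)methyl group on an aromatic carbon. In this assay compound 1 gives > 200000 nM, which is a limit of the assay rather than a number. Compound 2, `O=c1[nH]c(=O)n([C@H]2C[C@H](O)[C@@H](CO)O2)cc1C#Cc1ccccc1`, carries 2-phenylethynyl in place of (methylsulfonyl)methyl on an aromatic carbon. In this assay compound 2 gives > 200000 nM, which is also a limit. Compound 2 thus stands at the limit of > 200000 nM in this assay, at which 2 of the 2 values shown sit. The step that the two limits leave unreadable from compound 1 to compound 2 cannot be read in size, since both of its ends are limits.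

Compound 3, `C=CC#Cc1cn([C@H]2C[C@H](O)[C@@H](CO)O2)c(=O)[nH]c1=O`, differs from compound 2 by vinyl in place of phenyl on a triple-bonded carbon. Among the compounds with values here, the only measured step is the one from compound 1 to compound 2, and its size stays hidden because the limit of > 200000 nM in this assay, at which 2 of the 2 values shown sit, covers both ends, so no measured step shows how this change should move the number. With both neighbours resting at the same limit, the step of a number no higher from compound 2 to compound 3 (the limit leaves the size open) is expected to stay within the usual scatter, in no particular direction. For compound 3 the expected value is 200000 nM, with a range from 100000 nM to 500000 nM, and most likely the assay again reports only a limit.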

Compound 3, half-maximal inhibitory concentration: > 200000 nM
Compound 3: only a limit was reported; the forecaster's own chance of this, stated with the estimate: 80%; the middle value sits exactly at the limit.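

Compound 3 again gives only a limit of the assay and not a number, so neither its step from compound 1 nor its step from compound 2 can be read, as all three compounds rest at the same limit: the limit of > 200000 nM in this assay, at which 3 of the 3 values shown sit.

The compounds shown leave open whether exchanging these groups on the shared core changes the half-maximal inhibitory concentration at all, and by how much.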